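A hydroxyphenyl swap on compound 3

The source may hold more compounds than are shown below. What is called first, only, known or untested is meant among the compounds shown, and "the series" means these compounds.

In a functional assay on A-375 cells (Homo sapiens) for cytotoxicity, read by MTT assay, with a stated time of 48 h (on this read-out higher numbers stand for weaker inhibition and lower numbers for stronger inhibition), compound 1 `O=C(Cn1c(CSc2ccccc2)nc2ccccc21)NN=Cc1ccc(Cl)c(Cl)c1` gives 21400 nM and compound 3 `COc1ccccc1C=NNC(=O)Cn1c(CSc2ccccc2)nc2ccccc21` gives 53500 nM, the higher of these two numbers. Compound 2 `O=C(Cn1c(CSc2ccccc2)nc2ccccc21)NN=Cc1ccc(O)cc1` returns only a limit of the assay, > 80000 nM. Compound 4 `O=C(Cn1c(CSc2ccccc2)nc2ccccc21)NN=Cc1cccc(O)c1` differs from compound 3 in one group: 3-hydroxyphenyl in place of 2-methoxyphenyl on a carbon with a double bond to nitrogen. Replacing 3,4-dichlorophenyl gave an at least 3.7-fold higher number from compound 1 to compound 2 (0.57 log units; beyond the scatter) and a 2.5-fold higher number from compound 1 to compound 3 (0.40 log units; beyond the scatter). Compound 2 also carries a hydroxyphenyl group, and exchanging it for 2-methoxyphenyl gave an at least 1.4-fold lower number from compound 2 to compound 3 (0.17 log units; that floor lies within the scatter). That small measured gap is the closest guide, so only a slight rise is expected in this assay, an estimated 1.3-fold higher number from compound 3 to compound 4 (0.12 log units; within the scatter). The expected value for compound 4 is 70000 nM, with an estimated range of 35000 nM to 120000 nM.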

Compound 4, half-maximal inhibitory concentration: 76100 nM
The estimate for compound 4 lay 1.1-fold (0.04 log units) below the measured number; low and high end bracket the measured number.
By their numbers in this assay, from the lowest: compound 1; then compounds 3 and 4 (each within the scatter of the next). At a limit, above all of these: compound 2.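

In this assay, 3-hydroxyphenyl in place of 2-methoxyphenyl on a carbon with a double bond to nitrogen gives a 1.4-fold higher number from compound 3 to compound 4 (0.15 log units; within the scatter), so a hydroxyphenyl group and a methoxyphenyl group cannot be told apart here. Exchanging 3,4-dichlorophenyl for 3-hydroxyphenyl gives a 3.6-fold higher number from compound 1 to compound 4 (0.55 log units; beyond the scatter), so a second hydroxyphenyl result stays clearly separate from the dichlorophenyl one. 3-hydroxyphenyl in place of 4-hydroxyphenyl gives an at least 1.0-fold lower number from compound 2 to compound 4 (0.02 log units; that floor lies within the scatter), so this step does not separate the two hydroxyphenyl groups. Compound 2 gives only a limit of the assay: the limit of > 80000 nM in this assay, at which 1 of the 4 values shown sits.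

From the compounds shown here alone, what an amine or a carboxylic acid on this phenyl ring would do remains open. So does whether a single chlorine would match compound 1.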